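A few compounds are considered here, and "the series" means these few. Any claim that something is new, unique, unknown or untested is made for them only; others in the source may bear on it.

Of the compounds shown here, three built on a shared core have been measured, each carrying a different aryl group on the core: compound 1 `CCC1=C(O)c2c(oc(-c3ccc(CC(C)C)cc3)cc2=O)C(CC)(CC)C1=O`, compound 2 `CCC1=C(O)c2c(oc(-c3ccc(OC(F)(F)F)cc3)cc2=O)C(CC)(CC)C1=O` and compound 3 `CCC1=C(O)c2c(oc(-c3ccc(CBr)cc3)cc2=O)C(CC)(CC)C1=O`. In a functional assay on KB cells (Homo sapiens) for antiproliferative activity, read by sulforhodamine B assay, with a stated time of 3 days (a lower number here means that less compound is needed, a higher number that more compound is needed for the effect), compound 1 gives 29.3 uM and compound 2 gives 36.5 uM. For compound 3 this assay reports a limit rather than a number, > 46.5 uM. Compound 3 therefore stands at the edge of what this assay can show; that edge is the limit of > 46.5 uM in this assay, at which 1 of the 3 values shown sits. The two steps that lead to it are an at least 1.5-fold higher number from compound 1 to compound 3 (0.20 log units; that floor lies within the scatter) and an at least 1.2-fold higher number from compound 2 to compound 3 (0.10 log units; that floor lies within the scatter), and both floors lie within the scatter, so the three aryl variants cannot be ordered against each other on these numbers.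

Compound 4 `CCC1=C(O)c2c(oc(-c3ccc(O)c(C)c3C)cc2=O)C(CC)(CC)C1=O` is the next step from compound 3: 4-hydroxy-2,3-dimethylphenyl in place of 4-(bromomethyl)phenyl on an aromatic carbon. The change brings in a hydrogen-bond donor and acceptor where the aryl ring of compound 3 carried none. Within the data shown here, no measured step separates an aryl variant from the others beyond the scatter, and the swap into compound 4 is of the same kind, so the expected step of an at least 1.3-fold lower number from compound 3 to compound 4 (0.12 log units; that floor lies within the scatter) is small and in no firm direction. Compound 4 is estimated at 35 uM in this assay, with a range from 12 uM to 100 uM.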

Compound 4, concentration for half-maximal effect: 6.5 uM
The estimate for compound 4 lay 5.4-fold (0.73 log units) above the measured number; the measured number lies below the stated range.
By their numbers in this assay, from the lowest: compound 4; then compounds 1 and 2 (each within the scatter of the next). At a limit, above all of these: compound 3.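

In this assay, the aryl group on the shared core had given no step beyond the scatter among the first three compounds, but exchanging 4-(bromomethyl)phenyl for 4-hydroxy-2,3-dimethylphenyl gives one: an at least 7.1-fold lower number from compound 3 to compound 4 (0.85 log units; beyond the scatter). With this change, compound 4 at 6.5 uM stands under both compound 1 at 29.3 uM and compound 2 at 36.5 uM, so the aryl group at this place, next to the ring oxygen, can move the number in this assay and does not merely leave it within a narrow band. The step is a floor and not a full size, since its starting point is a limit: the limit of > 46.5 uM in this assay, at which 1 of the 4 values shown sits.

The compounds shown do not separate the contribution of the hydroxy group from that of the two methyl groups in 4-hydroxy-2,3-dimethylphenyl, so it stays open which part of the exchange carries the step. They also leave open whether an amine or a carboxylic acid in place of the hydroxy group would keep the number as low as that of compound 4.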